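The source may hold more compounds than are shown below. What is called first, only, known or untested is meant among the compounds shown, and "the series" means these compounds.

Measured so far in a functional assay on CHO-K1 cells for antagonist activity at transient receptor potential cation channel subfamily V member 1 (Homo sapiens), read by FLIPR; a lower number here means a stronger inhibitor, a higher number a weaker inhibitor:
compound 1 `CC(C(=O)NCc1ccc(C(F)(F)F)nc1N1CC=CCC1)c1ccc(NS(C)(=O)=O)c(F)c1` gives 12.1 nM
compound 2 `CC(C(=O)NCc1ccc(C(F)(F)F)nc1N1CCC2(CC1)CC(C(C)(C)C)=NO2)c1ccc(NS(C)(=O)=O)c(F)c1` gives 281 nM

Compound 2 holds the higher of the two numbers in this assay. Its nearest neighbour is compound 1, whose number sits well below it, a gap beyond the scatter of repeated runs. Among the compounds with values here, no single-point step between these two measured compounds is defined, so the comparison rests on the two values alone.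

Compound 3 `CC(C(=O)NCc1ccc(C(F)(F)F)nc1N1CCC2(CC1)CC(c1ccccc1)=NO2)c1ccc(NS(C)(=O)=O)c(F)c1` is the next compound in the series and has not yet been run in this assay. It differs from compound 2 as follows: phenyl in place of tert-butyl on a carbon with a double bond to nitrogen. Within the data shown here, no measured step covers this kind of exchange, so there is nothing to size it from.

For compound 3 the expectation is therefore a number close to that of compound 2, with the step of a 1.3-fold lower number from compound 2 to compound 3 (0.11 log units; within the scatter) judged as likely to stay within the scatter, or at most a modest move either way. The estimate for compound 3 in this assay is 220 nM, with a range from 60 nM to 800 nM.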

Compound 3, half-maximal inhibitory concentration: 289 nM
Compound 3: the middle estimate sits 1.3-fold (0.12 log units) below what was measured; the measured number falls inside the stated range.
By their numbers in this assay, from the lowest: compound 1; then compounds 2 and 3 (each within the scatter of the next).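

This position, on a carbon with a double bond to nitrogen of the five-membered non-aromatic ring with 1 nitrogen and 1 oxygen, now has its first measured exchange, and in this assay phenyl in place of tert-butyl gives a step within the scatter (a 1.0-fold higher number from compound 2 to compound 3 (0.01 log units; within the scatter)). Tert-butyl, with no ring and 4 heavy atoms, and phenyl, with one six-membered aromatic ring of carbon only and 6 heavy atoms, therefore read alike here, so this single pair gives no sign that this assay separates the two groups at this position. Nothing measured bears on why the two groups read alike.

Still open, from the compounds shown here alone, is whether the reading at this carbon holds for a much smaller group such as methyl, or for groups carrying nitrogen or oxygen, such as an amine, a carboxylic acid or a pyridine ring. Going by these compounds, it is also open whether a substituent on the phenyl itself, such as chlorine or methoxy, would move the number in this assay beyond the scatter.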